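A few compounds are considered here, and "the series" means these few. Any claim that something is new, unique, unknown or untested is made for them only; others in the source may bear on it.

Compound 1 `COc1cc(N(Cc2nc3ccccc3[nH]2)S(=O)(=O)c2ccc(F)cc2)cc(OC)c1OC` gives 9380 nM in a functional assay on MCF7 cells (Homo sapiens) for inhibition, read by MTT assay, with a stated time of 48 h; a lower number here means a stronger inhibitor, a higher number a weaker inhibitor. Compound 2 `COc1cc(N(Cc2nc3ccccc3[nH]2)C(=O)c2ccccc2)cc(OC)c1OC` gives > 50000 nM in this assay, which is a limit of the assay and not a number. Compound 3 `COc1cc(N(Cc2nc3ccccc3[nH]2)C(=O)c2ccc(Br)cc2)cc(OC)c1OC` gives > 50000 nM in this assay, likewise a limit of the assay.

Compound 3 therefore stands at the upper edge of what this assay reports, sharing that position with compound 2 (the limit of > 50000 nM in this assay, at which 2 of the 3 values shown sit). Only compound 1 has a read number, and the moves away from it are an at least 5.3-fold higher number from compound 1 to compound 2 (0.72 log units; beyond the scatter) and an at least 5.3-fold higher number from compound 1 to compound 3 (0.72 log units; beyond the scatter). Between the two carbonyl compounds the change is a step that the two limits leave unreadable from compound 2 to compound 3, so the effect of a substituent on that ring cannot be read from the data.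

Compound 4 `COc1cc(N(Cc2nc3ccccc3[nH]2)C(=O)c2ccc(C(C)(C)C)cc2)cc(OC)c1OC` differs from compound 3 by tert-butyl in place of bromo on an aromatic carbon. Among the compounds with values here, the one measured step that touches this position is the unreadable step from compound 2 to compound 3; the two readable steps concern the exchange of the sulfonyl for a carbonyl and say nothing about the group on the ring. With compound 3 itself sitting at a limit, no movement beyond the scatter in this assay can be expected, and the most likely outcome is another limit. Compound 4 is therefore estimated at 60000 nM, between 25000 nM and 150000 nM, the expected step being a step that the limit leaves unreadable from compound 3 to compound 4.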

Compound 4, half-maximal inhibitory concentration: 48800 nM
Compound 4: middle estimate off by 1.2-fold (0.09 log units), on the high side; measured number inside the range.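

Within the data shown here, with tert-butyl on this aromatic carbon, para to a large group, compound 4 gives 48800 nM in this assay, the first read number among the carbonyl compounds and so the first at this position. The readable steps are an at least 1.0-fold lower number from compound 3 to compound 4 (0.01 log units; that floor lies within the scatter) and an at least 1.0-fold lower number from compound 2 to compound 4 (0.01 log units; that floor lies within the scatter), so neither tert-butyl in place of bromo nor tert-butyl in place of hydrogen is shown to move the number beyond the scatter. What the result adds is therefore a firm number for one group at this position, while compound 2 and compound 3 remain limits of the assay and not numbers: the limit of > 50000 nM in this assay, at which 2 of the 4 values shown sit.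

The compounds shown leave open whether any group on this ring can bring a carbonyl compound near compound 1, which gives 9380 nM in this assay. From the compounds shown here alone, how an amine or a carboxylic acid would read at this position stays open as well, as does the effect of tert-butyl in place of fluoro on the sulfonyl compound.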